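Swapping the formyl tail for a nitrile: expected cytotoxicity

A few compounds are considered here, and "the series" means these few. Any claim that something is new, unique, unknown or untested is made for them only; others in the source may bear on it.

Compound 1 `COc1cc(CC(O)c2ccc(-c3ccc(C=O)cc3)cc2)c([N+](=O)[O-])cc1OC` was tested in an ADME assay on HeLa Rh cells (Homo sapiens) for cytotoxicity, read by microscopy; on this read-out higher numbers stand for lower toxicity in this test and lower numbers for higher toxicity in this test. In this assay compound 1 reaches only a limit of the assay, > 245000 nM, so its true value is not a number. Compound 2 `COc1ccc(-c2ccc(C(O)Cc3cc(OC)c(OC)cc3[N+](=O)[O-])cc2)cc1` carries a methoxy in place of the formyl; in this assay compound 2 likewise stops at a limit, > 244000 nM. Between them a step that the two limits leave unreadable from compound 1 to compound 2. Compound 3 `COc1cc(CC(O)c2ccc(-c3ccc(F)cc3)cc2)c([N+](=O)[O-])cc1OC` carries a fluoro in place of the formyl, and in this assay compound 3 gives 4500 nM. That change gives an at least 54-fold lower number from compound 1 to compound 3 (1.73 log units; beyond the scatter), and likewise an at least 54-fold lower number from compound 2 to compound 3 (1.73 log units; beyond the scatter).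

Compound 4 `COc1cc(CC(O)c2ccc(-c3cccc(C#N)c3)cc2)c([N+](=O)[O-])cc1OC` is not yet measured. (3-cyanophenyl in place of 4-formylphenyl on an aromatic carbon). Among the compounds with values here, no measured step swaps a whole ring tail in this way, so the fluoro and methoxy steps are only indirect guides: two of the three tails sit at a limit, while one gives a numbered value. Taking both outcomes as possible, compound 4 is expected to sit somewhere between them, with the step from compound 1 estimated as an at least 2.4-fold lower number from compound 1 to compound 4 (0.38 log units; beyond the scatter). The estimate for compound 4 in this assay is 100000 nM, with a range from 15000 nM to 245000 nM.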

Compound 4, half-maximal cytotoxic concentration: 5200 nM
Beside the measured number, compound 4's estimate is 19-fold (1.28 log units) above it, and the stated range ends above it.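

In this assay, the 3-cyanophenyl tail falls in with the 4-fluorophenyl tail and not with the two tails that stop at a limit: the step is a 1.2-fold higher number from compound 3 to compound 4 (0.06 log units; within the scatter), so compound 3 and compound 4 cannot be told apart in this test. Set against the formyl tail, the change gives an at least 47-fold lower number from compound 1 to compound 4 (1.67 log units; beyond the scatter), and set against the methoxy tail, it gives an at least 46-fold lower number from compound 2 to compound 4 (1.67 log units; beyond the scatter), so a low number at this place is no longer seen with the fluoro tail alone. Those two steps start from limits of the assay and not from numbers, so their sizes are floors, and the true gaps could be larger.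

Compound 4 differs from compound 3 in both the group and where it sits on the outer ring, so the compounds shown do not separate these two changes, and a nitrile where the fluoro of compound 3 sits would be needed to do so. They also leave open whether an amine or a carboxylic acid on this ring would give a number like those of compound 3 and compound 4 or stop at a limit like compound 1 and compound 2.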